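The source may hold more compounds than are shown below. What is called first, only, known or untested is meant among the compounds shown, and "the series" means these compounds.

Measured so far:
compound 1, `Fc1ccc(-c2cn3ccnc3c(-c3ccc4ncn(C5CCCCC5)c4c3)n2)cc1`: 3.49%
compound 2, `Brc1ccc(-c2cn3ccnc3c(-c3ccc4ncn(C5CCCCC5)c4c3)n2)cc1`: 23.3%

Both were tested in a functional assay on KM12 cells (Homo sapiens) for inhibition, read by sulforhodamine B assay, with a stated time of 48 h, tested at 10 uM; on this read-out higher numbers stand for more inhibition at the one concentration tested (going by the name of the read-out) and lower numbers for less inhibition. Compound 2, with 23.3%, holds the higher of the two numbers. For the measured compounds named here, compound 1 stands lower by the step of a number 19.8 percentage points higher from compound 1 to compound 2 (beyond the scatter), the only measured step, which consists of bromo in place of fluoro on an aromatic carbon.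

Compound 3, `Fc1ccccc1-c1cn2ccnc2c(-c2ccc3ncn(C4CCCCC4)c3c2)n1`, is not yet measured. It differs from compound 2 by 2-fluorophenyl in place of 4-bromophenyl on an aromatic carbon. Bromine here gives way to fluorine, which reverses the one measured change, but the fluorine now belongs to a 2-fluorophenyl, and no measured pair shows that arrangement. Going by the values given here, the single step that bears on the question, a number 19.8 percentage points higher from compound 1 to compound 2 (beyond the scatter), suggests a fall back toward the level of compound 1. The step expected from this change is a number 15.3 percentage points lower from compound 2 to compound 3 (beyond the scatter). Compound 3 is therefore estimated at 8%, with a likely range from -5% to 22%.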

Compound 3, a percentage reported as inhibition, at one concentration (the size of the read-out at that concentration, not a potency): 2.45%
Compound 3: the middle estimate sits 5.6 percentage points above what was measured; low and high end bracket the measured number.
By their numbers in this assay, from the lowest: compounds 3 and 1 (each within the scatter of the next); then compound 2.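

In this assay the change from 4-bromophenyl to 2-fluorophenyl gives a number 20.9 percentage points lower from compound 2 to compound 3 (beyond the scatter) and so does not keep the higher number of compound 2. Exchanging 4-fluorophenyl for 2-fluorophenyl gives a number 1 percentage points lower from compound 1 to compound 3 (within the scatter) and shows that, on these numbers, where the fluorine sits on the phenyl ring makes no readable difference; among these three compounds, only the 4-bromophenyl of compound 2 stands apart. Nothing measured here explains why the bromine-bearing ring stands apart.

Still open, going by these compounds, is whether a 2-bromophenyl would match the 4-bromophenyl, which would show whether bromine needs that particular place on the ring. On these data alone, it is also open whether a phenyl ring carrying chlorine, a methoxy group or an amine would land nearer compound 2 or compound 1.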